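Losing the trifluoromethyl group from compound 3

A few compounds are considered here, and "the series" means these few. Any claim that something is new, unique, unknown or untested is made for them only; others in the source may bear on it.

compound 1 `COC(=O)c1ccc(NC(=O)C2(C(=O)Nc3ccc(Nc4ncc5cc(C(=O)N(C)C)n(C6CCCC6)c5n4)cc3)CC2)cc1` gives 77.1%
compound 2 `Cc1ccc(NC(=O)C2(C(=O)Nc3ccc(Nc4ncc5cc(C(=O)N(C)C)n(C6CCCC6)c5n4)cc3)CC2)cc1` gives 40.2%
compound 3 `CN(C)C(=O)c1cc2cnc(Nc3ccc(NC(=O)C4(C(=O)Nc5cccc(C(F)(F)F)c5)CC4)cc3)nc2n1C1CCCC1` gives 15.7%

In a functional assay on A549 cells (Homo sapiens) for inhibition, read by CCK-8 assay, with a stated time of 72 h, tested at 1 uM (a higher number here means more inhibition of growth at the concentration tested, a lower number less inhibition of growth), compound 3 stands lowest of the three at 15.7% and its gaps to both others lie beyond the scatter. The next compound is compound 4 `CN(C)C(=O)c1cc2cnc(Nc3ccc(NC(=O)C4(C(=O)Nc5ccccc5)CC4)cc3)nc2n1C1CCCC1`, and the change is hydrogen in place of trifluoromethyl on an aromatic carbon. Among the compounds with values here, two measured steps bear on this. One is a number 24.5 percentage points lower from compound 2 to compound 3 (beyond the scatter), where 3-(trifluoromethyl)phenyl replaces 4-methylphenyl. The other is a number 61.4 percentage points lower from compound 1 to compound 3 (beyond the scatter), where it replaces 4-(methoxycarbonyl)phenyl. Within the data shown here, neither removes trifluoromethyl alone, and no compound carrying plain phenyl has been measured. Even so, compound 3 lies below both other substituted phenyl compounds, so a modest rise is expected, no larger than the smaller of those steps. The expected change is a number 16.3 percentage points higher from compound 3 to compound 4 (beyond the scatter) as an estimate, and a result within the scatter would not be surprising. For compound 4 the estimated value is 32% with an expected range from 14% to 52% in this assay here.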

Compound 4, percent growth inhibition at one concentration: 75%
The estimate for compound 4 lay 43 percentage points below the measured number, and the stated range ends below it.
By their numbers in this assay, from the lowest: compound 3; then compound 2; then compounds 4 and 1 (each within the scatter of the next).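

Taking trifluoromethyl off this ring in this assay gives a number 59.3 percentage points higher from compound 3 to compound 4 (beyond the scatter) and shows that the unsubstituted phenyl is no weak parent, as the substituted compounds alone had left room to suppose. Hydrogen also compares well with methyl, at a number 34.8 percentage points higher from compound 2 to compound 4 (beyond the scatter), so these two groups go with lower growth inhibition than hydrogen, while compound 1 goes against any rule that substituents here lower the number, with a number 2.1 percentage points lower from compound 1 to compound 4 (within the scatter) and so no gain from methoxycarbonyl over hydrogen. Nothing at hand explains why trifluoromethyl and methyl lower the number while methoxycarbonyl does not.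

The compounds shown do not separate the identity of a group from its place on this ring. On these data alone, whether an amine, a carboxylic acid or a longer chain on this ring would exceed plain phenyl remains open.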